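This account rests on a few compounds, and the source may have more. Where it says the series, first, only, none or still open, it means among the compounds named here.

Of the compounds shown here, three sharing one core have so far been tested in a functional assay on MKN-45 cells (Homo sapiens) for inhibition, with a stated time of 72 h (a lower number here means a stronger inhibitor, a higher number a weaker inhibitor), and compound 3 `COc1cc(C(=O)c2ccc3c(ccn3C)c2)cc(OC)c1OC` leads them. Compound 1 `COc1cc(C(=O)c2ccc3[nH]ccc3c2)cc(OC)c1OC` gives 88 nM here and compound 2 `COc1cc(C(=O)c2cccc3cc[nH]c23)cc(OC)c1OC` gives 210 nM here, while compound 3 reaches 11.2 nM as the lowest number of the three, which makes it the strongest inhibitor so far.

Compound 4 `CCn1ccc2cc(C(=O)c3cc(OC)c(OC)c(OC)c3)ccc21` alters compound 3 in one place, and the change amounts to methyl in place of hydrogen on a saturated chain carbon bound to an aromatic nitrogen in all: methyl in place of hydrogen on a saturated chain carbon bound to an aromatic nitrogen, which turns methyl into ethyl.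

Within the data shown here, one measured step bears on this. Putting methyl in place of hydrogen on an aromatic nitrogen gave a 7.9-fold lower number from compound 1 to compound 3 (0.90 log units; beyond the scatter) and so went beyond the scatter. Among the measured compounds shown here, that step covers only the first carbon on the nitrogen, and no compound with a longer chain has been measured. A repeat of that fall is not expected, and a reversal cannot be ruled out.

The expected change is a 1.8-fold higher number from compound 3 to compound 4 (0.25 log units; within the scatter) as a small move toward a weaker number, about the size of the scatter. Compound 4 is estimated at 20 nM within an expected range of 7 nM to 60 nM in this assay once measured.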

Compound 4, half-maximal inhibitory concentration: 31 nM
Beside the measured number, compound 4's estimate is 1.6-fold (0.19 log units) below it; measured number inside the range.
By their numbers in this assay, from the lowest: compound 3; then compound 4; then compound 1; then compound 2.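

At this nitrogen the effect of adding carbon does not run in one direction: the first carbon lowered the number, with a 7.9-fold lower number from compound 1 to compound 3 (0.90 log units; beyond the scatter) in this assay, but the second carbon raised it, with a 2.8-fold higher number from compound 3 to compound 4 (0.44 log units; beyond the scatter) as the result. Ethyl still improves on the bare nitrogen, since the direct comparison gives a 2.8-fold lower number from compound 1 to compound 4 (0.45 log units; beyond the scatter) and so shows that part of the gain from methyl survives the longer group. Among hydrogen, methyl and ethyl at this place, then, methyl gives the lowest number, and the second carbon takes back some of what the first one gained. Nothing shown here explains why the number rises again with the added carbon.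

The compounds shown leave open whether a propyl or a longer chain on this nitrogen would raise the number further, and whether a branched group such as isopropyl, or a chain ending in an amine or a carboxylic acid, would follow the same course. They also leave open whether a methyl or an ethyl on the nitrogen of compound 2 would produce similar steps.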